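A few compounds are considered here, and "the series" means these few. Any claim that something is new, unique, unknown or untested is made for them only; others in the source may bear on it.

Compound 1 `N#Cc1cc(C(=O)N2CS(=O)(=O)c3ccccc32)cc(C2CC2)c1O`: 19200 nM in an assay on tissue (RPTEC cells) for inhibition of solute carrier family 22 member 12 (Homo sapiens), read by scintillation counting, with stated times of 15 min and 2 h; a higher number here means a weaker inhibitor, a lower number a stronger inhibitor
Compound 2 `N#Cc1cc(C(=O)N2CS(=O)(=O)c3ccccc32)cc(C(F)(F)F)c1O`: in this assay only a limit, > 100000 nM
Compound 3 `CC(C)c1cc(C(=O)N2CS(=O)(=O)c3ccccc32)cc(C#N)c1O`: 83300 nM in this assay

Compound 3 gives the highest of the two numbers shown; its nearest neighbour is compound 1, with a 4.3-fold higher number from compound 1 to compound 3 (0.64 log units; beyond the scatter). Compound 4 `CCc1cc(C(=O)N2CS(=O)(=O)c3ccccc32)cc(C#N)c1O` differs from compound 3 by hydrogen in place of methyl on a saturated chain carbon bound to an aromatic carbon and a saturated chain carbon. Going by the values given here, two measured steps bear on a change of the group on that aromatic carbon: a 4.3-fold higher number from compound 1 to compound 3 (0.64 log units; beyond the scatter) and an at least 5.2-fold higher number from compound 1 to compound 2 (0.71 log units; beyond the scatter), both beyond the scatter, whereas an at least 1.2-fold lower number from compound 2 to compound 3 (0.07 log units; that floor lies within the scatter) lies within it. Changing isopropyl to ethyl is therefore expected to give a modest step downward in this assay, a 2.1-fold lower number from compound 3 to compound 4 (0.32 log units; beyond the scatter). Compound 4 is estimated at 40000 nM, with a range from 15000 nM to 100000 nM.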

Compound 4, half-maximal inhibitory concentration: > 100000 nM
Compound 4 was reported as a limit; the forecaster's own chance of this, stated with the estimate: 20%; middle value at least 2.5-fold (0.39 log units) from the limit.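

On these data alone, compound 4 is known in this assay only as a limit, so shortening isopropyl to ethyl brought no visible gain: the step is an at least 1.2-fold higher number from compound 3 to compound 4 (0.07 log units; that floor lies within the scatter) and stays open in size. Ethyl also joins the groups that fall short of cyclopropyl, with an at least 5.2-fold higher number from compound 1 to compound 4 (0.71 log units; beyond the scatter), leaving cyclopropyl as the only group here with a clearly lower number; the step between compound 2 and compound 4 cannot be read. The top of the range is crowded: the limit of > 100000 nM in this assay, at which 2 of the 4 values shown sit. As far as these compounds go, whether cyclobutyl, an amine or a longer chain on this aromatic carbon would match cyclopropyl stays open, as does how far compound 2 and compound 4 truly lie beyond their limits.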